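A few compounds are considered here, and "the series" means these few. Any claim that something is new, unique, unknown or untested is made for them only; others in the source may bear on it.

- compound 1 `CN1CCN(CC2CCN(c3nccc4[nH]c(-c5ccc(F)c(C(F)(F)F)c5)nc34)CC2)CC1` measured at 165000 nM
- compound 2 `CN1CCN(CC2CCN(c3nccc4[nH]c(-c5cccc(C(=O)N(C)C)c5)nc34)CC2)CC1` measured at 180000 nM
- compound 3 `CN1CCN(CC2CCN(c3nccc4[nH]c(-c5cccc(OCCN)c5)nc34)CC2)CC1` not yet measured

In a physicochemical assay for solubility, read by HPLC, using the shake flask method, in phosphate buffer, with a stated time of 20 h, at pH 6.5 (on this read-out higher numbers stand for higher solubility and lower numbers for lower solubility), compound 2 gives 180000 nM and so stands level with compound 1 at 165000 nM within the scatter. Going by the values given here, these are the only two numbers available so far.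

Compound 3 differs from compound 2 by 2-aminoethoxy in place of dimethylcarbamoyl on an aromatic carbon and so carries 2-aminoethoxy in place of dimethylcarbamoyl on an aromatic carbon. Among the compounds with values here, one measured step bears on this change, namely a 1.1-fold higher number from compound 1 to compound 2 (0.04 log units; within the scatter) with 3-(dimethylcarbamoyl)phenyl in place of 4-fluoro-3-(trifluoromethyl)phenyl. That step lies within the scatter, even though the two groups exchanged in it are quite different. Within the data shown here, no measured compound carries 2-aminoethoxy, however, so this single step offers only thin guidance. In this assay no step beyond the scatter is therefore expected, in either direction. The estimated move is a 1.1-fold higher number from compound 2 to compound 3 (0.02 log units; within the scatter) and would count as no real change. For compound 3 the estimate is 190000 nM with an expected range from 95000 nM to 380000 nM on this read-out.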

Compound 3, solubility: 200000 nM
The estimate for compound 3 lay 1.1-fold (0.02 log units) below the measured number; measured number inside the range.
By their numbers in this assay, from the lowest: compounds 1, 2 and 3 (each within the scatter of the next).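

In this assay, a third group on this aromatic carbon leaves the reading level: 2-aminoethoxy in place of dimethylcarbamoyl gives a 1.1-fold higher number from compound 2 to compound 3 (0.05 log units; within the scatter), and 3-(2-aminoethoxy)phenyl in place of 4-fluoro-3-(trifluoromethyl)phenyl gives a 1.2-fold higher number from compound 1 to compound 3 (0.08 log units; within the scatter). The change also swaps a group with no hydrogen-bond donor for one that has a hydrogen-bond donor, and neither step lies beyond the scatter, so among these three compounds this difference in the group comes with no real difference in the number. Nothing measured here accounts for why the three compounds stand level.

The compounds shown leave open whether a carboxylic acid, a longer chain ending in an amine, or 2-aminoethoxy with its amine capped by methyl groups would stay within the scatter on this aromatic carbon. They also leave open what a change elsewhere would do, for example replacing the methyl group on the terminal nitrogen of the shared core with a hydrogen, since all three compounds carry the same core and differ only in this one group.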